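Three Limits and an Untested Fourth Sulfonamide

The source may hold more compounds than are shown below. What is called first, only, known or untested is meant among the compounds shown, and "the series" means these compounds.

Three sulfonamides built on one shared core have been tested in an assay on cells for inhibition of HSP60/HSP10 (Homo sapiens), with a stated time of 60 min; on this read-out lower numbers stand for stronger inhibition and higher numbers for weaker inhibition. Compound 1 `COc1cccc(S(=O)(=O)Nc2ccc3oc(-c4ccccc4)nc3c2)c1` carries a 3-methoxyphenyl on the sulfonyl sulfur. In this assay compound 1 gives > 100000 nM, which is a limit of the assay and not a number. Compound 2 `O=S(=O)(Nc1ccc2oc(-c3ccccc3)nc2c1)c1cccc(Cl)c1` carries a 3-chlorophenyl instead. In this assay compound 2 gives > 100000 nM, again a limit rather than a number. Compound 3 `O=S(=O)(Nc1ccc2oc(-c3ccccc3)nc2c1)c1ccccc1Cl` carries a 2-chlorophenyl. In this assay compound 3 gives > 100000 nM, once more a limit. The difference between the cores of compound 2 and compound 3 is 2-chlorophenyl in place of 3-chlorophenyl on a sulfonyl sulfur. The change from compound 2 to compound 1 is methoxy in place of chloro on an aromatic carbon, and its step is a step that the two limits leave unreadable from compound 2 to compound 1, because both ends sit at the limit of > 100000 nM in this assay, at which 3 of the 3 values shown sit.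

Compound 4 `COc1ccccc1S(=O)(=O)Nc1ccc2oc(-c3ccccc3)nc2c1` has not been measured. It differs from compound 3 as methoxy in place of chloro on an aromatic carbon. Among the measured compounds shown here, this is the same kind of change as the one from compound 2 to compound 1, but not the same: there the methoxy sits meta to a large group, here ortho to a large group. The step expected in this assay is a step that the limit leaves unreadable from compound 3 to compound 4, resting on compound 3 and its > 100000 nM and on the three values all standing at the limit of > 100000 nM in this assay, at which 3 of the 3 values shown sit. Compound 4 is therefore estimated at 150000 nM, between 50000 nM and 500000 nM.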

Compound 4, half-maximal inhibitory concentration: > 100000 nM
Compound 4: no number, only a limit; the forecaster's own chance of this, stated with the estimate: 85%; the middle value is on the limit's open side.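

In this assay compound 4 gives > 100000 nM, a limit of the assay and not a number. Among the compounds shown here, no step from compound 1, compound 2 or compound 3 to compound 4 can be read, because every end of these comparisons is a limit: the limit of > 100000 nM in this assay, at which 4 of the 4 values shown sit. The compounds shown leave open how strongly any of the four inhibits, and whether any other group on the sulfonyl sulfur would give a measurable value.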